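Replacing a fluorophenyl with a methoxyanilino group

The source may hold more compounds than are shown below. What is called first, only, known or untested is meant among the compounds shown, and "the series" means these compounds.

Measured so far in an assay on CHO cells for displacement of a labelled ligand from prostaglandin E2 receptor EP1 subtype (Homo sapiens); a higher number here means a weaker inhibitor, a lower number a stronger inhibitor:
compound 1 `CCc1ccccc1N(Cc1nnc(Cc2ccc(Cl)cc2)o1)S(=O)(=O)c1ccc(C)cc1` gives 398 nM;
compound 2 `CCOc1ccc(Cc2nnc(CN(c3ccccc3CC)S(=O)(=O)c3ccc(C)cc3)o2)cc1` gives 126 nM;
compound 3 `Cc1ccc(S(=O)(=O)N(Cc2nnc(Cc3ccccc3F)o2)c2cccc(Cl)c2C)cc1` gives 501 nM.

Compound 3 has the highest number of the three, though its gap to compound 1 lies within the scatter, while compound 2 sits beyond it. Compound 4 `COc1ccc(NCc2nnc(CN(c3cccc(Cl)c3C)S(=O)(=O)c3ccc(C)cc3)o2)cc1` differs from compound 3 by (4-methoxyphenyl)amino in place of 2-fluorophenyl on a saturated chain carbon bound to an aromatic carbon. Going by the values given here, only one measured step touches this part of the molecule: a 3.2-fold lower number from compound 1 to compound 2 (0.50 log units; beyond the scatter), a modest gain from changing the substituent on the pendant ring. Among the compounds with values here, the present change is larger in kind and no measured pair mirrors it, so the expectation is loose. Compound 4 is expected to give 320 nM in this assay , a step of a 1.6-fold lower number from compound 3 to compound 4 (0.19 log units; within the scatter), with a range from 80 nM to 1500 nM.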

Compound 4, half-maximal inhibitory concentration: 20 nM
The estimate for compound 4 lay 16-fold (1.20 log units) above the measured number; measured number below the stated range.
By their numbers in this assay, from the lowest: compound 4; then compound 2; then compounds 1 and 3 (each within the scatter of the next).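

In this assay, (4-methoxyphenyl)amino in place of 2-fluorophenyl gives a large step (a 25-fold lower number from compound 3 to compound 4 (1.40 log units; beyond the scatter)), against the modest one seen earlier for a change on the pendant ring (a 3.2-fold lower number from compound 1 to compound 2 (0.50 log units; beyond the scatter)). So this position can respond far more strongly than the earlier compounds showed, and it accepts a group that brings in a nitrogen and a hydrogen-bond donor. Nothing measured here accounts for the gain. The step changes the ring substituents and the link together, so their shares stay unresolved. A plain phenylamino group or a cyclohexylamino group would help to separate them.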